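The compounds below may be only part of what the source reports. "The series", "measured", "known", "first", "only" and "open" are said of these compounds alone.

Measured compounds:
compound 1, `CCCS(=O)(=O)Nc1ccc(F)c(C(=O)c2n[nH]c3ncc(-c4ccc(F)cc4)cc23)c1F`: 2.1%
compound 2, `CCCS(=O)(=O)Nc1ccc(F)c(C(=O)c2n[nH]c3ncc(-c4ccc(F)cc4C)cc23)c1F`: 14%

In an assay for binding affinity to dual specificity mitogen-activated protein kinase kinase 4 (Homo sapiens), read by KINOMEscan, tested at 100 nM (a higher number here means a weaker effect of the compound at the concentration tested, a lower number a stronger effect), compound 1 gives 2.1%, while compound 2 gives 14%. Among these two numbers compound 2 stands highest; its only neighbour is compound 1, and the single measured step, a number 11.9 percentage points higher from compound 1 to compound 2 (beyond the scatter), is a modest rise that lies beyond the scatter.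

Compound 3, `CCCS(=O)(=O)Nc1ccc(F)c(C(=O)c2n[nH]c3ncc(-c4ccc(C(F)(F)F)cc4)cc23)c1F`, differs from compound 2 in one place: 4-(trifluoromethyl)phenyl in place of 4-fluoro-2-methylphenyl on an aromatic carbon. This change undoes the methyl that distinguishes compound 2 from compound 1, and at the same time exchanges the fluorine for a trifluoromethyl group. Within the data shown here, only the step from compound 1 to compound 2 bears on the first part of the change; for the second part no measured pair gives any guidance. Since removal of the methyl reverses a step of a number 11.9 percentage points higher from compound 1 to compound 2 (beyond the scatter), compound 3 is expected to move back toward the lower number of compound 1, with the trifluoromethyl group adding uncertainty in either direction. The estimated step is a number 8 percentage points lower from compound 2 to compound 3 (within the scatter). Compound 3 is therefore estimated at 6%, within a range from 1% to 25%.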

Compound 3, a percentage reported as activity, at one concentration (the size of the read-out at that concentration, not a potency): 29%
Estimate against measurement, compound 3: 23 percentage points below, outside the stated range (above it).
By their numbers in this assay, from the lowest: compound 1; then compound 2; then compound 3.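

In this assay, exchanging fluoro for trifluoromethyl on an otherwise unchanged compound gives a number 26.9 percentage points higher from compound 1 to compound 3 (beyond the scatter), so this position responds to more than the methyl seen earlier, and the group held at the 4-position of the phenyl ring matters in its own right. The other step, a number 15 percentage points higher from compound 2 to compound 3 (beyond the scatter), shows that a compound without the methyl can still read higher than one with it: the 4-(trifluoromethyl)phenyl group does not return the number toward that of compound 1, which stays at 2.1%, and so far both single changes on this phenyl group, methyl for hydrogen and trifluoromethyl for fluoro, raise the number in this assay. Nothing available explains why either change weakens the effect at this concentration.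

As far as these compounds go, whether a chloro or a methoxy group in place of the fluoro would keep the number close to that of compound 1 or raise it as trifluoromethyl does remains open, as does the outcome for an amine at the same place. The compounds shown also leave open how a methyl and a trifluoromethyl group would act together on one phenyl ring.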